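Removing one methoxy group from an aryl ring

A few compounds are considered here, and "the series" means these few. Any claim that something is new, unique, unknown or untested is made for them only; others in the source may bear on it.

The measured compounds and their values:
compound 1 `COc1cc(-c2cc(/C=C/C(=O)c3ccc(N)cc3)[nH]n2)cc(OC)c1OC` gives 76%
compound 2 `COc1ccc(-c2cc(/C=C/C(=O)c3ccc(N)cc3)[nH]n2)cc1OC` gives 89%
compound 3 `COc1cc(C(=O)/C=C/c2cc(-c3cc(OC)c(OC)c(OC)c3)n[nH]2)cc(OC)c1OC` gives 74%

These numbers come from a functional assay on PC-3 cells (Homo sapiens) for cytotoxicity, read by sulforhodamine B assay, with a stated time of 48 h, tested at 1 uM; a higher number here means a weaker effect of the compound at the concentration tested, a lower number a stronger effect. Compound 1 and compound 2 differ in one place: hydrogen in place of methoxy on an aromatic carbon. That single change moved the read-out by a number 13 percentage points higher from compound 1 to compound 2 (beyond the scatter). Compound 3 carries a different core; the difference between the two cores is not broken down here. Compound 3 has the lowest of the three numbers, and its value lies within the scatter of that of compound 1, while that of compound 2 lies beyond the scatter from it.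

Compound 4 `COc1ccc(-c2cc(/C=C/C(=O)c3cc(OC)c(OC)c(OC)c3)[nH]n2)cc1OC` is not yet measured. It is related to compound 3 by hydrogen in place of methoxy on an aromatic carbon, the same change, at a place described in the same words, as that from compound 1 to compound 2. Because a number 13 percentage points higher from compound 1 to compound 2 (beyond the scatter) was modest but beyond the scatter, a step of similar size is expected, namely a number 12 percentage points higher from compound 3 to compound 4 (beyond the scatter). Compound 4 is therefore estimated at 86%, with a range from 72% to 100%.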

Compound 4, a percentage reported as activity, at one concentration (the size of the read-out at that concentration, not a potency): 71%
Compound 4: middle estimate off by 15 percentage points, on the high side, outside the stated range (below it).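

In this assay, the same change of hydrogen in place of methoxy on an aromatic carbon, made on the core of compound 3, gave a number 3 percentage points lower from compound 3 to compound 4 (within the scatter). Set beside the earlier step, this shows that the change did not carry over from one core to the other in this series: the same change on two cores in this assay, a number 13 percentage points higher (beyond the scatter) from compound 1 to compound 2 and a number 3 percentage points lower (within the scatter) from compound 3 to compound 4, 16 percentage points apart, beyond the scatter of two such steps What it does not show is why the two cores part ways, and two pairs read at a single concentration give no rule for how the change behaves on the series as a whole.

The compounds shown leave open whether the step on a further core would resemble that on the core of compound 1 or that on the core of compound 3. They also leave open what a hydroxyl group or a chlorine atom would do on that same aromatic carbon, in place of the methoxy group, on either core.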